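The source may report more compounds than this note shows. Statements on the series, on what has been measured and on what is new or still open speak of the compounds shown alone.

Measured compounds in an ADME assay on MDBK cells (Bos taurus) for cytotoxicity, read by MTT assay; on this read-out lower numbers stand for higher toxicity in this test and higher numbers for lower toxicity in this test:
Compound 1 `CC(C)(C)CC(=O)N(CCCCCCN1C[C@H](O)[C@@H](O)[C@H](O)[C@H]1CO)C1CCCCC1`: compound 1 gives > 500000 nM, a limit of the assay.
Compound 2 `CC(C)(C)C(=O)N(CCCCCCN1C[C@H](O)[C@@H](O)[C@H](O)[C@H]1CO)c1ccc(F)cc1F`: compound 2 gives > 500000 nM, a limit of the assay.
Compound 3 `CC(=O)N(CCCCCCN1C[C@H](O)[C@@H](O)[C@H](O)[C@H]1CO)c1ccc(F)cc1F`: compound 3 gives > 500000 nM, a limit of the assay.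

Compound 2 stands only at a limit in this assay; no number is known for it, and the same holds for the other two compounds, all three sitting at the limit of > 500000 nM in this assay, at which 3 of the 3 values shown sit. Among the compounds with values here, the one single-point step among them, a step that the two limits leave unreadable from compound 2 to compound 3, is therefore unreadable in size and direction.

Compound 4 `CC(C)(C)C(=O)N(CCCCCCN1C[C@H](O)[C@@H](O)[C@H](O)[C@H]1CO)C1CCCCCC1` differs from compound 2 by cycloheptyl in place of 2,4-difluorophenyl on an amide-type nitrogen. Within the data shown here, no measured step touches this place: the change from compound 2 to compound 3 alters the group on the carbonyl carbon, not the substituent on the amide-type nitrogen. Compound 1, which carries cyclohexyl on that nitrogen, sits at the limit like compound 2, so nothing in the series points to a readable step.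

Compound 4 is therefore expected to sit at the limit as well, an estimated 600000 nM (range 300000 nM to 2000000 nM), meaning an expected step that the limit leaves unreadable from compound 2 to compound 4.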

Compound 4, half-maximal cytotoxic concentration: > 500000 nM
Compound 4 gave a limit, no number; the forecaster's own chance of this, stated with the estimate: 85%; the middle value lies beyond the limit too.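

Within the data shown here, compound 2 and compound 4 both stand at a limit in this assay, so no step between them can be read: the limit of > 500000 nM in this assay, at which 4 of the 4 values shown sit.

The compounds shown leave open at what concentration any of them turns toxic, and whether the group on the amide-type nitrogen matters at all.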